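The compounds below may be only part of what the source reports. "The series", "measured", "known", "first", "only" and "open" are said of these compounds alone.

Measured in a functional assay on cells (Cell line, plasma, Homo sapiens) for inhibition; on this read-out higher numbers stand for weaker inhibition and lower numbers for stronger inhibition:
- compound 1 `O=C(O)COc1cccc2c1CCC(COC(=O)N(c1ccccc1)c1ccccc1)=C2`: 91 nM
- compound 2 `O=C(O)COc1cccc2c1CC[C@H](COC(=O)N(c1ccccc1)c1ccccc1)[C@@H]2O`: 170 nM
- compound 3 `O=C(O)COc1cccc2c1CC[C@](O)(COC(=O)N(c1ccccc1)c1ccccc1)[C@H]2O`: 1300 nM

On this assay, compound 3 has the highest number of the three, which makes it the weakest inhibitor of this small set. Its gaps to compound 1 and to compound 2 both lie beyond the usual scatter of repeat measurements.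

The next compound to be tested is compound 4 `O=C(O)COc1cccc2c1CC[C@](O)(COC(=O)N(c1ccccc1)c1ccccc1)[C@@H]2O`. The change from compound 3 is the two compounds have the same atoms and bonds and differ only in configuration as drawn: 1 of 2 stereo elements differ; a stereocentre at a saturated ring carbon is drawn S in compound 3 and R in compound 4. Nothing is added or removed, so this is a pure test of three-dimensional arrangement: a stereocentre at a saturated ring carbon is drawn S in compound 3 and R in compound 4.

Going by the values given here, no measured pair here shows what such a switch does, so any forecast is uncertain and the range must be wide. The switch could matter a great deal or hardly at all. Compound 3 at 1300 nM sits well above compound 2 at 170 nM, so a move toward lower numbers seems more likely than a move further up. The expected step is a 1.9-fold lower number from compound 3 to compound 4 (0.27 log units; within the scatter), a modest gain in inhibition that may not clear the scatter. For compound 4 the estimated value is 700 nM, with an expected range from 150 nM to 3000 nM.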

Compound 4, half-maximal inhibitory concentration: 5.8 nM
Compound 4: middle estimate off by 120-fold (2.08 log units), on the high side; the whole stated range lies above it.
By their numbers in this assay, from the lowest: compound 4; then compounds 1 and 2 (each within the scatter of the next); then compound 3.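

In this assay, a single switch at a stereocentre on a saturated ring carbon gives a 220-fold lower number from compound 3 to compound 4 (2.35 log units; beyond the scatter), a large step that lies far outside the usual scatter of repeat measurements. The earlier compounds shown here gave no view of this, since none of them formed a pair differing in one place, and here the drawn S and R forms of that carbon turn out to be far from interchangeable. No atom or bond is gained or lost, so the gap can be put down to three-dimensional arrangement alone, because the comparison is a clean one: the fact that compounds 3 and 4 differ only in the configuration as drawn

The compounds shown leave open what the second stereocentre contributes, since it is drawn the same way in compound 3 and compound 4, and a switch there, alone or together with the first, could have a small effect or a large one. They also leave open whether the hydroxyl groups themselves are needed for this strong inhibition, a question that a methoxy group or an amine in their place would help to answer.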